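The compounds below may be only part of what the source reports. "The series", "measured", "known", "first", "only" and "open" are said of these compounds alone.

The measured compounds:
Compound 1, `CN1CCN(CC(=O)Nc2ccc(-c3nc4cc(C(F)(F)F)ccc4n3C)cc2)CC1`, gives 22000 nM in an ADME assay on MT4 cells (Homo sapiens) for cytotoxicity, read by MTT assay, with a stated time of 96 h; on this read-out higher numbers stand for lower toxicity in this test and lower numbers for higher toxicity in this test.
Compound 2, `CC(=O)Nc1ccc(-c2nc3cc(C(F)(F)F)ccc3n2C)cc1`, gives 15000 nM in this assay.
Compound 3, `Cn1c(-c2ccc(N)cc2)nc2cc(C(F)(F)F)ccc21`, gives 20000 nM in this assay.

Compound 3 stands second highest of the three numbers, but every gap around it is small: the step of a 1.1-fold lower number from compound 1 to compound 3 (0.04 log units; within the scatter) and the step of a 1.3-fold higher number from compound 2 to compound 3 (0.12 log units; within the scatter) both sit within the scatter, as does the step of a 1.5-fold lower number from compound 1 to compound 2 (0.17 log units; within the scatter) between the other two. All three measured changes concern the nitrogen on an aromatic ring of the 4-aminophenyl group and the chain attached to it.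

Compound 4, `Nc1ccc(-c2nc3cc(C(F)(F)F)ccc3n2C2CCCCC2)cc1`, differs from compound 3 by cyclohexyl in place of methyl on an aromatic nitrogen. Among the measured compounds shown here, this change sits on the shared core, at a place none of the measured steps touches, so no measured step bears directly on it. What the measured steps do show is a read-out in this assay that barely moved across three changes of quite different size elsewhere in the molecule, and no pattern beyond that can be drawn from three compounds.

The step of a 1.3-fold lower number from compound 3 to compound 4 (0.12 log units; within the scatter) is therefore expected to stay within the scatter, with the range widened for the lack of a directly relevant comparison. Compound 4 is estimated to give about 15000 nM in this assay, between 5000 nM and 45000 nM.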

Compound 4, half-maximal cytotoxic concentration: 44000 nM
Compound 4: the middle estimate sits 2.9-fold (0.47 log units) below what was measured; the range from low to high includes it.
By their numbers in this assay, from the lowest: compounds 2, 3, 1 and 4 (each within the scatter of the next, the first and the last beyond it).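

In this assay, among the compounds shown here, the step of a 2.2-fold higher number from compound 3 to compound 4 (0.34 log units; beyond the scatter) is the first in this short series to lie beyond the scatter, and it arises on the aromatic nitrogen of the five-membered aromatic ring, a place that the earlier compounds left unchanged. The three earlier steps, all confined to the nitrogen of the 4-aminophenyl group and the chain attached to it, stayed within the scatter, whereas this modest step shows that replacing methyl, with 1 heavy atom, by cyclohexyl, with 6 heavy atoms and a non-aromatic ring, can move this read-out towards lower toxicity in this test. No information given here accounts for this step.

With only methyl and cyclohexyl shown at this position, it remains open whether the ring itself matters or simply the number of carbons, a question that an open chain such as n-hexyl, a smaller ring such as cyclopropyl or a short group such as ethyl could address. From the compounds shown here alone, it also remains open whether cyclohexyl would give a step of similar size with the acetyl or ((4-methylpiperazin-1-yl)methyl)carbonyl group on the nitrogen of the 4-aminophenyl group.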